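Cyano Removal on the Fused Core of Compound 3

The source may report more compounds than this note shows. Statements on the series, on what has been measured and on what is new or still open speak of the compounds shown alone.

Working notes on a small set sharing one core with a pyridinyl group and a cyclopropyl group. Compound 1 `c1cncc(-c2nc3ccccc3n2C2CC2)c1` is the bare member. In an assay on V79 cells for inhibition of cytochrome P450 11B1, mitochondrial (Homo sapiens), read by HTRF, with a stated time of 1 h (on this read-out lower numbers stand for stronger inhibition and higher numbers for weaker inhibition), compound 1 gives > 8330 nM, a limit of the assay and not a number. Compound 2 `CS(=O)(=O)c1ccc2c(c1)nc(-c1cccnc1)n2C1CC1` adds a methylsulfonyl on an aromatic carbon. In this assay compound 2 gives > 10000 nM, again a limit. Going by the values given here, the one single-change step, a step that the two limits leave unreadable from compound 1 to compound 2, stays unreadable because of the limit of > 8330 nM in this assay, at which 1 of the 3 values shown sits, and (the limit of > 10000 nM in this assay, at which 1 of the 3 values shown sits).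

Compound 3 `N#Cc1cc2c(cc1F)nc(-c1cccnc1)n2C1CC1` carries cyano and fluoro. In this assay compound 3 gives 117 nM. Among the compounds with values here, this is the only number among the three values shown; the other two are limits of the assay. Compound 4 `Fc1ccc2c(c1)nc(-c1cccnc1)n2C1CC1` differs from compound 3 by hydrogen in place of cyano on an aromatic carbon. Within the data shown here, no measured step removes a cyano, and the only measured step concerns a different group on a different member, so nothing directly sized bears on this change; the two values of compound 1 and compound 3 are all there is, with no single-change step between them.

The expected step is a 17-fold higher number from compound 3 to compound 4 (1.23 log units; beyond the scatter), toward weaker inhibition and beyond the scatter. Compound 4 is expected to give about 2000 nM, in the range 400 nM to 9000 nM.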

Compound 4, half-maximal inhibitory concentration: 3980 nM
Compound 4: middle estimate off by 2.0-fold (0.30 log units), on the low side, within the range that was stated.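

Going by these compounds alone, the cyano group on this aromatic carbon, ortho to a fluoro group, now has a sized effect in this assay: a 34-fold higher number from compound 3 to compound 4 (1.53 log units; beyond the scatter), and this is the first step in the set with two real numbers at its ends, so nearly all of the measurable inhibition of compound 3 is lost with the cyano group. Fluoro in place of hydrogen on an aromatic carbon gives an at least 2.0-fold lower number from compound 1 to compound 4 (0.32 log units; beyond the scatter), a modest gain next to the cyano step, and its size can be stated only as a bound because one end is a limit of the assay and not a number: the limit of > 8330 nM in this assay, at which 1 of the 4 values shown sits. Fluoro in place of methylsulfonyl gives an at least 2.5-fold lower number from compound 2 to compound 4 (0.40 log units; beyond the scatter), which is likewise only a bound because one end is a limit of the assay and not a number: the limit of > 10000 nM in this assay, at which 1 of the 4 values shown sits.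

The compounds shown do not tell whether cyano would give a step of this size with hydrogen in place of the fluoro group. Nor do they tell how an amine, a carboxylic acid or an amide on this aromatic carbon would compare with cyano in this assay.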